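Adding a chlorine to the benzoxazolone amide series

The source may report more compounds than this note shows. Statements on the series, on what has been measured and on what is new or still open speak of the compounds shown alone.

Three compounds share a core and differ in what hangs off the amide. Compound 1 `O=C(Cn1c(=O)oc2cc(Cl)ccc21)Nc1ccccc1` gives 20.2% in an ADME assay on RAW264.7 cells (Mus musculus) for cytotoxicity, read by MTT assay, with a stated time of 72 h, tested at 100 uM; a higher number here means a stronger effect of the compound at the concentration tested, a lower number a weaker effect. For the measured compounds named here, compound 2 `O=C(Cn1c(=O)oc2cc(Cl)ccc21)NCc1ccco1` gives 50.3%, and the change a number 30.1 percentage points higher from compound 1 to compound 2 (beyond the scatter) is the only step recorded so far. Compound 3 `O=C(Cn1c(=O)oc2ccccc21)Nc1ccccn1` gives 28.4%, which puts it second highest of the three: close to compound 1, with a gap within the scatter, and well below compound 2, with a gap beyond the scatter.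

Compound 4 `O=C(Cn1c(=O)oc2cc(Cl)ccc21)Nc1ccccn1` has not been measured. It differs from compound 3 in one place: chloro in place of hydrogen on an aromatic carbon. Going by the values given here, compounds 1 and 2 already carry this chloro group, but no recorded step isolates its effect on its own, so the one measured step does not bear on it directly. With no evidence for a shift in either direction, the expected step of a number 1.6 percentage points higher from compound 3 to compound 4 (within the scatter) is none beyond the scatter. Compound 4 is therefore estimated at 30%, within a range from 15% to 47%.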

Compound 4, a percentage reported as inhibition, at one concentration (the size of the read-out at that concentration, not a potency): 43.7%
Estimate against measurement, compound 4: 13.7 percentage points below; measured number inside the range.
By their numbers in this assay, from the lowest: compounds 1 and 3 (each within the scatter of the next); then compounds 4 and 2 (each within the scatter of the next).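

For the compounds shown here, the step of a number 15.3 percentage points higher from compound 3 to compound 4 (beyond the scatter) is the first to isolate chloro in place of hydrogen on an aromatic carbon, and it shows that in this assay this single-atom change moves the number beyond the scatter. With the chloro present, the group on the amide nitrogen also counts: pyridin-2-yl in place of phenyl gives a number 23.5 percentage points higher from compound 1 to compound 4 (beyond the scatter), whereas pyridin-2-yl in place of (furan-2-yl)methyl gives a number 6.6 percentage points lower from compound 2 to compound 4 (within the scatter), so those two groups cannot be told apart here. Nothing measured here explains these shifts.

Going by these compounds alone, only one pair isolates the chloro, so whether it acts the same way alongside phenyl or (furan-2-yl)methyl on the amide nitrogen stays open. Also open, as far as these compounds go, is whether fluoro, methoxy or an amine on that aromatic carbon would shift the number as chloro does.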